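Oxazole substituent variation in a diacylglycerol lipase-alpha series

A few compounds are considered here, and "the series" means these few. Any claim that something is new, unique, unknown or untested is made for them only; others in the source may bear on it.

Measured so far:
compound 1 `O=C(CCCCCCc1ccccc1)c1nc(C(=O)C(F)(F)F)co1`: 123 nM
compound 2 `O=C(CCCCCCc1ccccc1)c1nc(C(F)(F)F)co1`: 214 nM
compound 3 `CS(=O)(=O)c1coc(C(=O)CCCCCCc2ccccc2)n1`: 389 nM

All three share one core and differ only in the group on the aromatic carbon of the five-membered ring. In an assay on HEK-293T cells for inhibition of diacylglycerol lipase-alpha (Homo sapiens), read by colorimetric assay (a higher number here means a weaker inhibitor, a lower number a stronger inhibitor), compound 1 gives 123 nM, and compound 3 gives 389 nM, the highest of the three numbers. Against compound 2 the gap is a 1.8-fold higher number from compound 2 to compound 3 (0.26 log units; within the scatter), so these two cannot be ordered; against compound 1 it is a 3.2-fold higher number from compound 1 to compound 3 (0.50 log units; beyond the scatter), a modest but real difference.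

Compound 4 `CC(C)(C)C(=O)c1coc(C(=O)CCCCCCc2ccccc2)n1` is not yet measured. The change from compound 3 is (tert-butyl)carbonyl in place of methylsulfonyl on an aromatic carbon.

Going by the values given here, two measured steps bear on this. The step of a 3.2-fold higher number from compound 1 to compound 3 (0.50 log units; beyond the scatter) shows that exchanging a (trifluoromethyl)carbonyl for a methylsulfonyl raised the number modestly; the step of a 1.7-fold higher number from compound 1 to compound 2 (0.24 log units; within the scatter) shows that removing the carbonyl while keeping the trifluoromethyl stayed within the scatter. Compound 4 restores a carbonyl but with a tert-butyl rather than a trifluoromethyl on it, for which no direct comparison exists. The expectation for compound 4 is therefore a step of a 1.4-fold lower number from compound 3 to compound 4 (0.14 log units; within the scatter), a small lowering toward the range of compound 2, with wide uncertainty. The estimated value for compound 4 in this assay is 280 nM, within 90 nM to 900 nM.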

Compound 4, half-maximal inhibitory concentration: 479 nM
The estimate for compound 4 lay 1.7-fold (0.23 log units) below the measured number; the range from low to high includes it.
By their numbers in this assay, from the lowest: compounds 1, 2, 3 and 4 (each within the scatter of the next, the first and the last beyond it).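

In this assay, (tert-butyl)carbonyl and methylsulfonyl on this aromatic carbon cannot be told apart (a 1.2-fold higher number from compound 3 to compound 4 (0.09 log units; within the scatter)), although the two groups differ in heavy atoms, double bonds outside aromatic rings and hydrogen-bond acceptors. Compounds 1 and 4 give the first comparison in which the carbonyl stays in place and only the group on it changes, and tert-butyl in place of trifluoromethyl makes a modest but real difference (a 3.9-fold higher number from compound 1 to compound 4 (0.59 log units; beyond the scatter)), so among these compounds a carbonyl at this position does not by itself match compound 1. Compound 4 also separates from compound 2 (a 2.2-fold higher number from compound 2 to compound 4 (0.35 log units; beyond the scatter)), a modest difference beyond the scatter, whereas the step between compound 2 and compound 3 stayed within it.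

The measurements shown offer no evidence for why these steps take the sizes they do. Going by these compounds, it remains open where a methyl or a cyclopropyl on the carbonyl would fall between compound 1 and compound 4, and how a nitrile, a primary amide or a carboxylic acid would read on the same aromatic carbon.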